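The source may report more compounds than this note shows. Statements on the series, on what has been measured and on what is new or still open speak of the compounds shown alone.

Working notes on the series. In a functional assay on MV4-11 cells (Homo sapiens) for antiproliferative activity, read by resazurin assay, with a stated time of 72 h (a higher number here means a weaker inhibitor of growth, a lower number a stronger inhibitor of growth), compound 1, `CC(=O)N1CCN(c2ccc(Nc3nccc(-c4c[nH]c5cccnc45)n3)cc2)CC1`, gives 420 nM, and compound 2, `CN1CCN(c2cccc(Nc3nccc(-c4cn(C)c5ncccc45)n3)c2)CC1`, gives 24 nM. Compound 2 therefore holds the lower of the two numbers, and the gap to compound 1 lies beyond the scatter. Compound 3, `CN1CCN(c2cccc(Nc3nccc(-c4c[nH]c5cccnc45)n3)c2)CC1`, is not yet measured. It departs from compound 2 by a single change: a group of 9 heavy atoms (7 carbon, 2 nitrogen; one five-membered aromatic ring with 1 hetero atom, one six-membered aromatic ring with 1 hetero atom) in place of a group of 10 heavy atoms (8 carbon, 2 nitrogen; one five-membered aromatic ring with 1 hetero atom, one six-membered aromatic ring with 1 hetero atom), on an aromatic carbon. Among the compounds with values here, no measured pair isolates this change. Within the data shown here, the only measured compound carrying the entering group is compound 1 at 420 nM, but compound 1 also differs elsewhere, so that value gives only a weak hint towards a higher number. The expected result in this assay is a modest move towards weaker growth inhibition, estimated as a 2.5-fold higher number from compound 2 to compound 3 (0.40 log units; beyond the scatter), and a result within the scatter would not be surprising. For compound 3 the estimated value is 60 nM, with an expected range of 15 nM to 250 nM.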

Compound 3, concentration for 50% growth inhibition: 405 nM
Compound 3: middle estimate off by 6.8-fold (0.83 log units), on the low side, and the stated range ends below it.
By their numbers in this assay, from the lowest: compound 2; then compounds 3 and 1 (each within the scatter of the next).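

With the rest of the molecule held constant, exchanging the group on the aromatic carbon next to the ring nitrogen gives, in this assay, a 17-fold higher number from compound 2 to compound 3 (1.23 log units; beyond the scatter). The earlier compounds shown here differed in more than one place and could not isolate this position; this pair shows that growth inhibition depends strongly on the group held there, with the entering group having 1 hydrogen-bond donor and the leaving group 0 hydrogen-bond donors. Nothing available explains the size of this step.

The compounds shown leave open which difference between the two groups carries the step. Also open, as far as these compounds go, is how an ethyl group or a longer chain in place of the methyl of the leaving group would read in this assay.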